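One Methoxy Fewer: What Compound 4 Might Show

This account rests on a few compounds, and the source may have more. Where it says the series, first, only, none or still open, it means among the compounds named here.

Compound 1, `COc1cc(-c2cc(/C=C/C(=O)c3ccc(N)cc3)[nH]n2)cc(OC)c1OC`: 5690 nM
Compound 2, `COc1ccc(-c2cc(/C=C/C(=O)c3ccc(N)cc3)[nH]n2)cc1OC`: 36100 nM
Compound 3, `COc1cc(C(=O)/C=C/c2cc(-c3cc(OC)c(OC)c(OC)c3)n[nH]2)cc(OC)c1OC`: 5490 nM

Of the compounds shown here, three have been measured in a functional assay on SK-MEL-5 cells (Homo sapiens) for inhibition, read by sulforhodamine B assay, with a stated time of 48 h; on this read-out higher numbers stand for lower toxicity in this test and lower numbers for higher toxicity in this test. Compound 1 `COc1cc(-c2cc(/C=C/C(=O)c3ccc(N)cc3)[nH]n2)cc(OC)c1OC` gives 5690 nM. Compound 2 `COc1ccc(-c2cc(/C=C/C(=O)c3ccc(N)cc3)[nH]n2)cc1OC` differs from compound 1 by one change, (hydrogen in place of methoxy on an aromatic carbon). In this assay compound 2 gives 36100 nM, and the step is a 6.3-fold higher number from compound 1 to compound 2 (0.80 log units; beyond the scatter). Compound 3 `COc1cc(C(=O)/C=C/c2cc(-c3cc(OC)c(OC)c(OC)c3)n[nH]2)cc(OC)c1OC` gives 5490 nM in this assay, a value within the scatter of that of compound 1. The difference between the core of compound 1 and the core of compound 3 is not broken down here.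

Compound 4 `COc1ccc(-c2cc(/C=C/C(=O)c3cc(OC)c(OC)c(OC)c3)[nH]n2)cc1OC` has not yet been measured. It differs from compound 3 by hydrogen in place of methoxy on an aromatic carbon. Going by the values given here, this is the same change as the one from compound 1 to compound 2, and the surroundings of the place are described in the same words in both cases; among the four compounds it occurs twice. Since the measured instance gave a 6.3-fold higher number from compound 1 to compound 2 (0.80 log units; beyond the scatter), a step of similar size is expected here, resting on that single measured pair and on the value of compound 3, 5490 nM. Compound 4 is therefore expected to give about 30000 nM in this assay, most likely between 10000 nM and 90000 nM. This estimate corresponds to an expected step of a 5.5-fold higher number from compound 3 to compound 4 (0.74 log units; beyond the scatter).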

Compound 4, concentration lethal to 50% of the cells: 5440 nM
Compound 4: the middle estimate sits 5.5-fold (0.74 log units) above what was measured; the whole stated range lies above it.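

In this assay, replacing the methoxy group with hydrogen on this second core gave a 1.0-fold lower number from compound 3 to compound 4 (0.00 log units; within the scatter), so the large step seen on the first core did not appear here. The same change therefore cannot be carried from one core to the other in this series as a fixed step, and the two instances disagree: the same change on two cores in this assay, a 6.3-fold higher number (0.80 log units; beyond the scatter) from compound 1 to compound 2 and a 1.0-fold lower number (0.00 log units; within the scatter) from compound 3 to compound 4, 6.4-fold (0.81 log units) apart, beyond the scatter of two such steps. This shows only that the size of the step differed between these two pairs; it does not show which feature of the cores separates them, nor how the change would behave on any further core, and a single pair on each core gives no sense of how general either result is.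

The compounds shown leave open which part of the difference between the core of compound 1 and the core of compound 3 goes with the gap between the two steps, as no compound here alters that part on its own. They also leave open whether a hydroxyl group, a fluorine atom or a longer alkoxy chain at the same place would follow the first step, the second step or neither.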